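A Second Fluoro on the Phenyl Ring

The source may hold more compounds than are shown below. What is called first, only, known or untested is meant among the compounds shown, and "the series" means these compounds.

Compound 1 `CCCCCCCC1OOC2CCCC(c3ccccc3)(OO1)O2`: 12000 nM
Compound 2 `c1ccc(C23CCCC(OOC(C4CCCCC4)OO2)O3)cc1`: 10000 nM
Compound 3 `Fc1ccc(C2OOC3CCCC(c4ccccc4)(OO2)O3)cc1`: 17000 nM

In a functional assay on FM3A cells (Mus musculus) for cytotoxicity (a higher number here means that more compound is needed for the effect, a lower number that less compound is needed), compound 3 gives 17000 nM, which lies within the scatter of both other values, so the three compounds cannot be ranked. Compound 4 `Fc1ccc(C2OOC3CCCC(c4ccc(F)cc4)(OO2)O3)cc1` keeps the structure of compound 3 with one change, fluoro in place of hydrogen on an aromatic carbon, which turns phenyl to 4-fluorophenyl.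

Among the measured compounds shown here, no measured step makes this exact change. The closest evidence comes from swapping groups on a saturated ring carbon. Putting 4-fluorophenyl in place of heptyl gave a 1.4-fold higher number from compound 1 to compound 3 (0.15 log units; within the scatter), and putting it in place of cyclohexyl gave a 1.7-fold higher number from compound 2 to compound 3 (0.23 log units; within the scatter). Even cyclohexyl in place of heptyl gave only a 1.2-fold lower number from compound 1 to compound 2 (0.08 log units; within the scatter). These three compounds show little sensitivity to such swaps, though they say nothing directly about the new site.

In this assay the expected result is no shift beyond the scatter, an estimated 1.1-fold lower number from compound 3 to compound 4 (0.05 log units; within the scatter). For compound 4 the estimated value is 15000 nM, with an expected range from 7000 nM to 30000 nM.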

Compound 4, half-maximal effective concentration: 9000 nM
Compound 4: middle estimate off by 1.7-fold (0.22 log units), on the high side, within the range that was stated.
By their numbers in this assay, from the lowest: compounds 4, 2, 1 and 3 (each within the scatter of the next).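

Fluoro in place of hydrogen, on an aromatic carbon of a six-membered aromatic ring and para to a large group, gives a 1.9-fold lower number from compound 3 to compound 4 (0.28 log units; within the scatter) in this assay. Among the compounds shown here, the earlier steps covered only swaps on a saturated ring carbon, so this is the first reading at this aromatic position, and here too the change of one atom does not move the number beyond the usual scatter. Nothing measured here gives a reason for this result or bears on the role of the fluoro.

On these data alone, it remains open whether an amine or a carboxylic acid at this same position would shift the number beyond the scatter. As far as these compounds go, it is also open whether fluoro here would read the same with the heptyl of compound 1 or the cyclohexyl of compound 2 on the saturated ring carbon.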